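The compounds below may be only part of what the source reports. "The series", "measured", "known", "first", "only" and "open" are said of these compounds alone.

Measured compounds in an assay on membranes from brain for binding affinity to Adrenergic receptor alpha-1 (Rattus norvegicus); on this read-out lower numbers stand for stronger inhibition and higher numbers for weaker inhibition:
- compound 1, `c1ccc(CC2CCN(Cc3nc4ccccc4[nH]3)CC2)cc1`, gives 2800 nM
- compound 2, `CS(=O)(=O)Nc1ccc2nc(CN3CCC(Cc4ccccc4)CC3)[nH]c2c1`, gives 1500 nM
- compound 3, `c1ccc(Oc2ccc(Cc3nc4ccccc4[nH]3)cc2)cc1`, gives 4200 nM

Compound 3 carries the highest number of the three. Its gap to compound 1 is within the scatter, so the two cannot be ordered; its gap to compound 2 is beyond the scatter, so compound 2 does stand at a lower number than compound 3.

Compound 4, `O=[N+]([O-])c1ccc2[nH]c(Cc3ccc(Oc4ccccc4)cc3)nc2c1`, is not yet measured. Relative to compound 3 the change is nitro in place of hydrogen on an aromatic carbon. For the measured compounds named here, the only measured step that bears on this is the one from compound 1 to compound 2, where a substituent also enters an aromatic carbon of the shared core in place of hydrogen: a 1.9-fold lower number from compound 1 to compound 2 (0.27 log units; within the scatter). That substituent is a methanesulfonamido group, not a nitro group, and the core of compound 1 differs from that of compound 3 in the group attached to it, so the comparison is loose. Going by the values given here, still, the one available precedent shows a substituent on the core moving the number only modestly downward, within the scatter.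

For compound 4 the expected step is therefore small, a 1.4-fold lower number from compound 3 to compound 4 (0.15 log units; within the scatter), and the estimate in this assay is 3000 nM with a range from 1200 nM to 8000 nM.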

Compound 4, half-maximal inhibitory concentration: 1200 nM
The estimate for compound 4 lay 2.5-fold (0.40 log units) above the measured number, and the stated range covers the measured number.
By their numbers in this assay, from the lowest: compounds 4, 2, 1 and 3 (each within the scatter of the next, the first and the last beyond it).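

In this assay, nitro in place of hydrogen on an aromatic carbon of the shared core gives a 3.5-fold lower number from compound 3 to compound 4 (0.54 log units; beyond the scatter) and so marks this carbon of the fused ring system as a place where one substituent can move the number beyond the scatter. For the compounds shown here, the only earlier step of this kind, a 1.9-fold lower number from compound 1 to compound 2 (0.27 log units; within the scatter) and a methanesulfonamido group entering, stayed within the scatter; since the two steps differ both in the entering group and in the rest of the molecule, neither difference alone can be held responsible for the contrast. Nothing on hand bears on what lies behind the new step.

Going by these compounds, whether an amine or a carboxylic acid on the same aromatic carbon would move the number as nitro does remains open, and so does whether nitro on another carbon of that ring would give a step of similar size. On these data alone, it is also open whether nitro would give a step beyond the scatter on the core of compound 1, which carries a different attached group.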